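A few compounds are considered here, and "the series" means these few. Any claim that something is new, unique, unknown or untested is made for them only; others in the source may bear on it.

Measured compounds:
- compound 1 `Nc1cc(N)c2nc(-c3ccccc3)c(Oc3ccc(Cl)c(Cl)c3)nc2c1`: < 100000 nM
- compound 2 `Nc1cc(N)c2nc(-c3ccccc3)c(NCc3ccc(Cl)c(Cl)c3)nc2c1`: < 100000 nM
- compound 3 `COc1cc(CNc2nc3cc(N)cc(N)c3nc2-c2ccccc2)cc(OC)c1OC`: 31600 nM

All three share one core and differ only in the group attached to it. They were tested in a functional assay on OVCAR-8 cells (Homo sapiens) for inhibition, read by sulforhodamine B assay, with a stated time of 48 h; a higher number here means that more compound is tolerated, a lower number that less compound is tolerated. For compound 1 the result is only a limit, < 100000 nM, not a number. For compound 2 the result is likewise only a limit, < 100000 nM. Among the measured compounds shown here, compound 3 is the one compound of the three for which this assay returned an actual number, 31600 nM; the other two results sit at the limit of < 100000 nM in this assay, at which 2 of the 3 values shown sit. Because no two of the measured compounds differ in a single place, no measured step can be read from them.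

The next compound, compound 4 `COc1ccc(CNc2nc3cc(N)cc(N)c3nc2-c2ccccc2)cc1OC`, differs from compound 3 in one place: hydrogen in place of methoxy on an aromatic carbon. One methoxy group is taken away, and the rest of the molecule stays the same. For the measured compounds named here, with no measured step to lean on, the expectation rests on the small size of this change: the step from compound 3 to compound 4 is expected to stay within the usual scatter, a 1.1-fold higher number from compound 3 to compound 4 (0.04 log units; within the scatter), with no clear direction. In this assay compound 4 is therefore estimated at 35000 nM, expected to fall between 12000 nM and 100000 nM.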

Compound 4, concentration lethal to 50% of the cells: < 100000 nM
Compound 4 gave a limit, no number (the forecaster's own chance of this, stated with the estimate: 25%); the middle value lies beyond the limit too.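

In this assay compound 4 gives only a limit, < 100000 nM, not a number. Its steps from compound 3 and from compound 2 therefore cannot be read. The compounds shown leave open whether hydrogen in place of methoxy, or 3,4-dimethoxyphenyl in place of 3,4-dichlorophenyl, changes the result at all, with most results resting on one limit: the limit of < 100000 nM in this assay, at which 3 of the 4 values shown sit.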